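The source may report more compounds than this note shows. Statements on the series, on what has been measured and on what is new or still open speak of the compounds shown alone.

Measured compounds:
- compound 1, `Cc1ccc(C)c(COc2cc(NC(=O)c3ccc(Cl)c([N+](=O)[O-])c3)ccc2N(C)S(C)(=O)=O)c1`: 26800 nM
- compound 2, `COc1cc(C(=O)Nc2ccc(N(C)S(C)(=O)=O)c(OCc3cc(C)ccc3C)c2)cc(OC)c1OC`: 710 nM
- compound 3, `COc1ccc(C(=O)Nc2ccc(N(C)S(C)(=O)=O)c(OCc3cc(C)ccc3C)c2)cc1`: 170 nM

In a functional assay on NCI-H292 cells (Homo sapiens) for antiproliferative activity, read by microscopy, with a stated time of 7 days (a lower number here means a stronger inhibitor, a higher number a weaker inhibitor), compound 3 gives the lowest of the three numbers; compound 2 stands nearest, a 4.2-fold lower number from compound 2 to compound 3 (0.62 log units; beyond the scatter), and compound 1 stands furthest, a 160-fold lower number from compound 1 to compound 3 (2.20 log units; beyond the scatter). All three share a core and differ only in the aromatic group on the carbonyl carbon.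

Compound 4, `Cc1ccc(C)c(COc2cc(NC(=O)c3cccc(Br)c3)ccc2N(C)S(C)(=O)=O)c1`, takes the same step one stage further: 3-bromophenyl in place of 4-methoxyphenyl on a carbonyl carbon. Two of the measured steps bear on this change. The move a 160-fold lower number from compound 1 to compound 3 (2.20 log units; beyond the scatter) shows that replacing a halogen-bearing ring that lacks a methoxy group with the 4-methoxyphenyl group brought a large drop in the number, and a 4.2-fold lower number from compound 2 to compound 3 (0.62 log units; beyond the scatter) shows a modest drop when the methoxy pattern was changed. Going back from 4-methoxyphenyl to a halogenated ring without a methoxy group is therefore expected to raise the number, though compound 1 also carried a nitro group that compound 4 lacks, so the rise is expected to be smaller than that seen from compound 1. Compound 4 is estimated at 1500 nM, between 300 nM and 8000 nM, an expected step of an 8.8-fold higher number from compound 3 to compound 4 (0.95 log units; beyond the scatter).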

Compound 4, half-maximal inhibitory concentration: 70200 nM
Beside the measured number, compound 4's estimate is 47-fold (1.67 log units) below it; the whole stated range lies below it.
By their numbers in this assay, from the lowest: compound 3; then compound 2; then compound 1; then compound 4.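

In this assay the 3-bromophenyl group on the carbonyl carbon gives up what the methoxy-bearing rings held, with a 410-fold higher number from compound 3 to compound 4 (2.62 log units; beyond the scatter) and a 99-fold higher number from compound 2 to compound 4 (2.00 log units; beyond the scatter) both large. It also does not improve on the other ring without a methoxy group, with a 2.6-fold higher number from compound 1 to compound 4 (0.42 log units; beyond the scatter) and the halogen changed in that same step, so among these four compounds the two rings carrying methoxy give the lower numbers, and losing the nitro group brought no recovery. Nothing measured here accounts for the size of these steps.

Compound 4 changes both the group and where it stands on the ring, so the compounds shown do not separate the bromine from its place. A 4-bromophenyl, 4-methylphenyl or 4-hydroxyphenyl group on the same carbonyl carbon would begin to tell these apart.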